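From a 2-chlorophenyl urea to a cyclohexyl urea

The compounds below may be only part of what the source reports. "The series", "measured", "known", "first", "only" and "open" are said of these compounds alone.

Of the compounds shown here, three sharing one core have been measured in a functional assay on MCF7 cells (Homo sapiens) for antiproliferative activity, read by MTT assay; on this read-out lower numbers stand for stronger inhibition and higher numbers for weaker inhibition. Compound 1 `COc1cc2c(Oc3ccc(NC(=O)Nc4ccccc4)cc3)ccnc2cc1OCCCCCCC(=O)NO` gives 1040 nM. Compound 2 `COc1cc2c(Oc3ccc(NC(=O)Nc4ccccc4Cl)cc3)ccnc2cc1OCCCCCCC(=O)NO` gives 2780 nM, the highest of the three numbers; the nearest is compound 1, separated by a 2.7-fold higher number from compound 1 to compound 2 (0.43 log units; beyond the scatter), and the furthest is compound 3 `COc1cc2c(Oc3ccc(NC(=O)Nc4ccc(C(F)(F)F)cc4Cl)cc3)ccnc2cc1OCCCCCCC(=O)NO`, which gives 500 nM. The remaining steps among the measured compounds are a 5.6-fold lower number from compound 2 to compound 3 (0.75 log units; beyond the scatter) and a 2.1-fold lower number from compound 1 to compound 3 (0.32 log units; beyond the scatter).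

Compound 4 `COc1cc2c(Oc3ccc(NC(=O)NC4CCCCC4)cc3)ccnc2cc1OCCCCCCC(=O)NO` has not yet been measured. It differs from compound 2 in one place: cyclohexyl in place of 2-chlorophenyl on an amide-type nitrogen. None of the three measured steps involves a change of this kind; each of them alters a substituent on an aromatic ring that stays in place, whereas here the aromatic ring itself gives way to a non-aromatic one. So no measured step bears directly on this change, and the expectation can rest only on the spread of the three known numbers, which is modest. One therefore expects compound 4 to give about 1500 nM, within a range from 500 nM to 5000 nM. That estimate corresponds to an expected step of a 1.9-fold lower number from compound 2 to compound 4 (0.27 log units; within the scatter), with no firm basis for a direction beyond the scatter.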

Compound 4, half-maximal inhibitory concentration: 600 nM
The estimate for compound 4 lay 2.5-fold (0.40 log units) above the measured number, within the range that was stated.
By their numbers in this assay, from the lowest: compounds 3, 4 and 1 (each within the scatter of the next, the first and the last beyond it); then compound 2.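

In this assay, the step from 2-chlorophenyl to cyclohexyl on this amide-type nitrogen, the only change shown that removes the aromatic ring itself rather than altering a substituent on it, gives a 4.6-fold lower number from compound 2 to compound 4 (0.67 log units; beyond the scatter) and so shows that an aromatic ring is not required here for a number in the range of the better compounds. Set against the phenyl and the 2-chloro-4-(trifluoromethyl)phenyl groups, cyclohexyl cannot be told apart, with a 1.7-fold lower number from compound 1 to compound 4 (0.24 log units; within the scatter) and a 1.2-fold higher number from compound 3 to compound 4 (0.08 log units; within the scatter) both within the scatter, so that among the four groups only 2-chlorophenyl stands apart from it. No supporting data accompany these numbers, and the reason for this behaviour at this position remains unexplained.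

From the compounds shown here alone, what a cyclopentyl ring, a piperidine ring or an open hexyl chain on this nitrogen would give remains open. So does the question of whether a hydroxyl group or a chloro substituent on the cyclohexyl ring would shift the number in the way that chloro and trifluoromethyl shifted it on the phenyl ring.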